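The source may report more compounds than this note shows. Statements on the series, on what has been measured and on what is new or still open speak of the compounds shown alone.

Measured compounds:
Compound 1, `Cn1ccnc1Sc1cnc(-c2ccncc2)nc1-c1ccccc1O`: 64700 ug/mL
Compound 2, `CC(C)(C)c1ncc(Sc2nc[nH]n2)c(-c2cc(Cl)ccc2O)n1`: 9580 ug/mL

Going by the values given here, in an ADME assay on MDCK cells (Canis lupus familiaris) for cytotoxicity (a higher number here means that more compound is tolerated, a lower number that less compound is tolerated), compound 1 gives 64700 ug/mL, the higher of the two numbers known so far, while compound 2 gives 9580 ug/mL; the gap between these two lies beyond the usual scatter of repeated measurements. Compound 3, `Cn1ccnc1Sc1cnc(N)nc1-c1ccccc1O`, has not yet been measured in this assay. It differs from compound 1 in one place: amino in place of pyridin-4-yl on an aromatic carbon. Among the compounds with values here, no pair of measured compounds differs in just this way, so there is no measured step to lean on, and compound 2 differs from compound 1 in several places at once. The change replaces a ring with an amino group on the shared core. The expectation is that the step of a 1.1-fold higher number from compound 1 to compound 3 (0.03 log units; within the scatter) stays within the scatter, with no clear move in either direction. Compound 3 is estimated at 70000 ug/mL, with a range from 25000 ug/mL to 200000 ug/mL.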

Compound 3, half-maximal cytotoxic concentration: 388000 ug/mL
The estimate for compound 3 lay 5.5-fold (0.74 log units) below the measured number, outside the stated range (above it).
By their numbers in this assay, from the lowest: compound 2; then compound 1; then compound 3.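

In this assay, putting amino in place of pyridin-4-yl on the aromatic carbon between two ring nitrogen atoms gives a 6.0-fold higher number from compound 1 to compound 3 (0.78 log units; beyond the scatter), so the group at this position can clearly change how much compound the cells tolerate. It also shows that, on this shared core, the pyridin-4-yl ring is not required for a high number, as the much smaller amino group gives a higher one. Nothing available explains why the number rises.

The compounds shown cannot separate a gain from the amino group itself from a gain from losing the ring, and a methyl or methylamino group at this position would help to tell these apart. On these data alone, this is also a single pair, so whether the same change gives a similar step on other cores remains open.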